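Aryl-substituted dichlorobenzimidazoles: three inactive analogues and a prediction

The compounds below may be only part of what the source reports. "The series", "measured", "known", "first", "only" and "open" are said of these compounds alone.

Measured compounds in a functional assay on CEM-SS cells (Homo sapiens) for cytotoxicity; on this read-out lower numbers stand for stronger inhibition and higher numbers for weaker inhibition:
Compound 1 `Clc1ccc(Cn2c(Cl)nc3cc(Cl)c(Cl)cc32)cc1` gives > 100000 nM, which is a limit of the assay.
Compound 2 `Cc1ccc(Cn2c(Cl)nc3cc(Cl)c(Cl)cc32)cc1` gives > 100000 nM, also a limit.
Compound 3 `Clc1cccc(Cn2c(Cl)nc3cc(Cl)c(Cl)cc32)c1` gives > 100000 nM, again a limit.

All three values sit at the same limit (the limit of > 100000 nM in this assay, at which 3 of the 3 values shown sit), so no ranking among them can be read. The change from compound 1 to compound 2 is methyl in place of chloro on an aromatic carbon, and its step that the two limits leave unreadable from compound 1 to compound 2 cannot be sized, as both ends are limits. Compound 4 `Cc1cccc(Cn2c(Cl)nc3cc(Cl)c(Cl)cc32)c1` relates to compound 3 through (methyl in place of chloro on an aromatic carbon); this is the same kind of change as from compound 1 to compound 2, but the place differs: para to a large group there, meta to a large group here. The difference between the cores of compound 1 and compound 3 is not broken down here.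

Compound 4 is expected to remain at the limit, with a step that the limit leaves unreadable from compound 3 to compound 4 from compound 3, because every measured value sits at the limit of > 100000 nM in this assay, at which 3 of the 3 values shown sit. The estimate for compound 4 is 200000 nM, with a range from 60000 nM to 1000000 nM.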

Compound 4, half-maximal inhibitory concentration: > 100000 nM
Compound 4 ended at the assay's limit; the forecaster's own chance of this, stated with the estimate: 90%; the middle value does not contradict the limit.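

The step between compound 3 and compound 4 cannot be read, because both values are limits: the limit of > 100000 nM in this assay, at which 4 of the 4 values shown sit.

The compounds shown leave open how chloro and methyl would rank on this shared core, and at what concentration, if any, any of the four would register an effect.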